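The source may report more compounds than this note shows. Statements on the series, on what has been measured and on what is new or still open speak of the compounds shown alone.

Measured compounds:
compound 1 `Cc1noc(C)c1-c1cnc(N)c(Oc2ccc(C(=O)Nc3ccccc3)cc2)n1`: 10500 nM
compound 2 `Cc1noc(C)c1-c1cnc(N)c(Oc2ccc(C(=O)Nc3ccc(Cl)cc3)cc2)n1`: 2230 nM

Compound 1 and compound 2 share one core and differ only in the group carried on the amide nitrogen. In a functional assay on HeLa cells (Homo sapiens) for inhibition, read by MTT assay, with a stated time of 72 h (on this read-out higher numbers stand for weaker inhibition and lower numbers for stronger inhibition), compound 1 gives 10500 nM, the higher of the two numbers, while compound 2 gives 2230 nM. Among the compounds with values here, the one measured step is a 4.7-fold lower number from compound 1 to compound 2 (0.67 log units; beyond the scatter), a modest but clear drop.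

Compound 3 `Cc1noc(C)c1-c1cnc(N)c(Oc2ccc(C(=O)Nc3ccc(Cl)cn3)cc2)n1` has not yet been measured in this assay. It differs from compound 1 by 5-chloropyridin-2-yl in place of phenyl on an amide-type nitrogen. Only part of this change has a measured counterpart: the chloro is the part covered by a 4.7-fold lower number from compound 1 to compound 2 (0.67 log units; beyond the scatter). The exchange of a ring of carbon only for a ring with one hetero atom has no measured counterpart among these compounds, so its contribution is unknown.

On the strength of that one step, compound 3 is expected to give a lower number than compound 1, by an amount beyond the scatter. Compound 3 is estimated at 3000 nM, within a range of 900 nM to 10000 nM. That corresponds to an expected step of a 3.5-fold lower number from compound 1 to compound 3 (0.54 log units; beyond the scatter).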

Compound 3, half-maximal inhibitory concentration: 19200 nM
Beside the measured number, compound 3's estimate is 6.4-fold (0.81 log units) below it; measured number outside the range, above it.
By their numbers in this assay, from the lowest: compound 2; then compounds 1 and 3 (each within the scatter of the next).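

In this assay, the result shows that this position responds to the ring on the amide-type nitrogen and not only to the chloro it carries: with a chloro present in both, 5-chloropyridin-2-yl in place of 4-chlorophenyl gives an 8.6-fold higher number from compound 2 to compound 3 (0.93 log units; beyond the scatter), which is beyond the scatter. Set against the unsubstituted phenyl, the same group gives a 1.8-fold higher number from compound 1 to compound 3 (0.26 log units; within the scatter), so the lower number that came with the chloro in a 4.7-fold lower number from compound 1 to compound 2 (0.67 log units; beyond the scatter) does not carry over to the ring with one hetero atom, and this full change leaves no difference that can be read beyond the scatter. Nothing available bears on what lies behind this result.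

The compounds shown leave open how a plain pyridin-2-yl, without the chloro, would read in this assay, and so how far the ring nitrogen and the chloro each contribute on their own. They also leave open whether a pyridin-3-yl ring would give the same result, and whether a methoxy group or a fluoro in place of the chloro would follow the phenyl series or the pyridine one.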